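Changing the amine aryl group: a cytotoxicity reading still to come

A few compounds are considered here, and "the series" means these few. Any claim that something is new, unique, unknown or untested is made for them only; others in the source may bear on it.

Of the compounds shown here, three have been measured in a functional assay on MCF7 cells (Homo sapiens) for cytotoxicity, read by MTT assay, with a stated time of 24 h; on this read-out higher numbers stand for weaker inhibition and lower numbers for stronger inhibition. Compound 1 `O=C(CN1CCN(c2ccccc2Cl)CC1)N1CCN(c2nnc(-c3ccccc3)c(-c3ccccc3)n2)CC1` gives 263000 nM. Compound 2 `COc1cccc(N2CCN(CC(=O)N3CCN(c4nnc(-c5ccccc5)c(-c5ccccc5)n4)CC3)CC2)c1` reaches only the limit of this assay, > 910000 nM. Compound 3 `O=C(CN1CCN(c2ccccc2Cl)CC1)N1CCN(c2nnc(-c3ccc(Cl)cc3)c(-c3ccc(Cl)cc3)n2)CC1` gives 396000 nM; against compound 1 this is an at least 3.4-fold higher number from compound 1 to compound 2 (0.53 log units; beyond the scatter) is not the relevant comparison, rather compound 3 and compound 1 lie within the scatter of each other, and the difference between their two cores is not broken down here.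

Within the data shown here, the single counted change runs from compound 1 to compound 2: 3-methoxyphenyl in place of 2-chlorophenyl on an amine nitrogen in a ring. It made an at least 3.4-fold higher number from compound 1 to compound 2 (0.53 log units; beyond the scatter), the value of compound 2 being a limit (the limit of > 910000 nM in this assay, at which 1 of the 3 values shown sits).

Compound 4 `COc1cccc(N2CCN(CC(=O)N3CCN(c4nnc(-c5ccc(Cl)cc5)c(-c5ccc(Cl)cc5)n4)CC3)CC2)c1` is not yet measured. It stands to compound 3 as compound 2 stands to compound 1: 3-methoxyphenyl in place of 2-chlorophenyl on an amine nitrogen in a ring. Since the place is the same word for word, this is the same change.

In this assay compound 4 is expected to show a 3.3-fold higher number from compound 3 to compound 4 (0.52 log units; beyond the scatter), resting on the step from compound 1 to compound 2, an at least 3.4-fold higher number from compound 1 to compound 2 (0.53 log units; beyond the scatter), and on the value of compound 3, 396000 nM. The estimate for compound 4 is 1300000 nM, between 500000 nM and 4000000 nM, with a real chance that only a limit is reported.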

Compound 4, half-maximal inhibitory concentration: 149000 nM
Compound 4: the middle estimate sits 8.7-fold (0.94 log units) above what was measured; measured number outside the range, below it.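

In this assay, putting 3-methoxyphenyl in place of 2-chlorophenyl on an amine nitrogen in a ring gave a 2.7-fold lower number from compound 3 to compound 4 (0.42 log units; beyond the scatter), so the change did not carry over from the core of compound 1 to the core of compound 3 with the direction it had before. Set side by side, the two steps run opposite ways, and the gap between them is real: the same change on two cores in this assay, an at least 3.4-fold higher number (0.53 log units; beyond the scatter) from compound 1 to compound 2 and a 2.7-fold lower number (0.42 log units; beyond the scatter) from compound 3 to compound 4, at least 9.1-fold (0.96 log units) apart, beyond the scatter of two such steps. Compound 2 gives > 910000 nM, which is a limit and not a number, and these two pairs show that the effect of this change depends on the core here, but not why it reverses or how general that reversal is.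

The compounds shown leave open whether other groups on the same amine nitrogen, such as an unsubstituted phenyl or a benzyl, would also behave differently on the two cores. They also leave open whether a 3-chlorophenyl there would follow compound 2 and compound 4 or part from them.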